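Compound 1 and its aromatic carbon methyl

The compounds below may be only part of what the source reports. "The series", "measured", "known", "first", "only" and "open" are said of these compounds alone.

Measured in a functional assay on HeLa cells (Homo sapiens) for inhibition, read by cell counting, with a stated time of 4 days; on this read-out higher numbers stand for weaker inhibition and lower numbers for stronger inhibition:
compound 1 `COc1ccc(N(C)c2nc(C)nc3c2nc(C)n3C)cc1` gives 4500 nM
compound 2 `COc1ccc(Nc2nc(C)nc3c2nc(C)n3C)cc1` gives 197000 nM
compound 3 `Cc1nc(N(C)c2ccc(OC(F)(F)F)cc2)c2nc(C)n(C)c2n1` gives 188000 nM

Compound 1 holds the lowest number of the three, and both other compounds lie beyond the scatter from it. Compound 4 `COc1ccc(N(C)c2nc(C)nc3c2ncn3C)cc1` is still unmeasured. The change from compound 1 is hydrogen in place of methyl on an aromatic carbon.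

Two measured steps offer partial guidance: a 44-fold higher number from compound 1 to compound 2 (1.64 log units; beyond the scatter) and a 42-fold higher number from compound 1 to compound 3 (1.62 log units; beyond the scatter). Both were large and both raised the number, but they changed a nitrogen substituent and an oxygen substituent. Going by the values given here, no measured step touches this aromatic carbon, so their size carries over poorly. Any change from compound 1 has so far raised the number, as a 44-fold higher number from compound 1 to compound 2 (1.64 log units; beyond the scatter) shows, so a moderate rise in this assay is expected, smaller than either measured step. The expected change is a 2.2-fold higher number from compound 1 to compound 4 (0.35 log units; beyond the scatter). For compound 4 the estimated value is 10000 nM, with an expected range from 2500 nM to 60000 nM.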

Compound 4, half-maximal inhibitory concentration: 22000 nM
For compound 4 the middle estimate is 2.2-fold (0.34 log units) below the measured one; the measured number falls inside the stated range.
By their numbers in this assay, from the lowest: compound 1; then compound 4; then compounds 3 and 2 (each within the scatter of the next).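

The methyl on this aromatic carbon of the five-membered aromatic ring is not neutral in this assay: replacing it with hydrogen gives a 4.9-fold higher number from compound 1 to compound 4 (0.69 log units; beyond the scatter). This step is smaller than a 44-fold higher number from compound 1 to compound 2 (1.64 log units; beyond the scatter) and a 42-fold higher number from compound 1 to compound 3 (1.62 log units; beyond the scatter), so of the three single changes from compound 1, the one at this carbon costs the least on this read-out. Nothing available bears on the reason for this step.

Going by these compounds, whether an ethyl group, a longer chain or a chlorine atom on this aromatic carbon would keep, lower or raise the number remains open. On these data alone, it is also open whether the change from methyl to hydrogen here would have a similar size in a compound carrying hydrogen in place of methyl on the nitrogen.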